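Removing a Bromine: What Compound 3 Might Show

The compounds below may be only part of what the source reports. "The series", "measured", "known", "first", "only" and "open" are said of these compounds alone.

Of the compounds shown here, two built on one shared core have been measured in a functional assay on MCF7 cells (Homo sapiens) for cytotoxicity; a higher number here means a weaker inhibitor, a lower number a stronger inhibitor. Compound 1 `O=C(N/N=C\c1cn(Cc2ccc(Cl)cc2)c2cc(F)ccc12)c1c[nH]c2ccccc12` carries a fluoro group on that core, and in this assay compound 1 gives 6000 nM. Compound 2 `O=C(N/N=C\c1cn(Cc2ccc(Cl)cc2)c2ccc(Br)cc12)c1c[nH]c2ccccc12` carries a bromo group in a different spot, and in this assay compound 2 gives 3200 nM. Among the compounds with values here, compound 2 has the lowest of the two numbers, yet its only neighbour, compound 1, differs from it by an amount that lies within the usual scatter, so the two cannot be told apart with confidence.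

The change from compound 2 to compound 3 `O=C(N/N=C\c1cn(Cc2ccc(Cl)cc2)c2ccccc12)c1c[nH]c2ccccc12` is hydrogen in place of bromo on an aromatic carbon; the bromine is simply gone and the ring is bare at that point. Within the data shown here, no measured pair shows this exact change, so the size of the step cannot be read from the data. Both substituted compounds sit at similar, moderate potency, and a bare ring is expected to land near them or somewhat weaker. The step is estimated to be a 1.6-fold higher number from compound 2 to compound 3 (0.19 log units; within the scatter). Compound 3 is therefore expected to give about 5000 nM, with a likely range from 2000 nM to 15000 nM.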

Compound 3, half-maximal inhibitory concentration: 96700 nM
Compound 3: the middle estimate sits 19-fold (1.29 log units) below what was measured; measured number outside the range, above it.
By their numbers in this assay, from the lowest: compounds 2 and 1 (each within the scatter of the next); then compound 3.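

Neither of the two earlier compounds could show how much a substituent on this ring contributes, and the bare ring now gives the answer: in this assay, hydrogen in place of bromo on an aromatic carbon is a large loss (a 30-fold higher number from compound 2 to compound 3 (1.48 log units; beyond the scatter)), not a small shift. Hydrogen in place of fluoro, at a different spot on the ring, is also a large loss (a 16-fold higher number from compound 1 to compound 3 (1.21 log units; beyond the scatter)), so among these three compounds the unsubstituted one is clearly the weakest, and each of the two groups, at its own position, goes with a much lower number than the bare ring. Why removing either group has such a large effect cannot be told, as nothing measured here speaks to the cause.

The compounds shown leave open whether this gain is particular to bromo and fluoro or whether other groups on the same aromatic carbon, such as chloro, methyl, methoxy or an amine, would also restore the lower numbers. They also leave open whether having groups at both positions on one ring would lower the number further than either group does alone.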